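The source may report more compounds than this note shows. Statements on the series, on what has been measured and on what is new or still open speak of the compounds shown alone.

The shared core is a sugar-bearing bicyclic ring system. Compound 1 `Cc1nc(N)c2c(-c3ccccc3)cn([C@@H]3O[C@H](CO)[C@@H](O)[C@H]3O)c2n1` is measured in a functional assay on HCT-116 cells (Homo sapiens), read by MTT assay, with a stated time of 72 h; a higher number here means a weaker inhibitor, a lower number a stronger inhibitor. In this assay compound 1 gives > 100000 nM, which is a limit of the assay rather than a number. Two further compounds stand beside it. Compound 2 `Nc1nc(N)c2c(-c3ccccc3)cn([C@@H]3O[C@H](CO)[C@@H](O)[C@H]3O)c2n1` differs from compound 1 by amino in place of methyl on an aromatic carbon. In this assay compound 2 gives > 20000 nM, again a limit rather than a number. The step that the two limits leave unreadable from compound 1 to compound 2 therefore cannot be read. Compound 3 `C#Cc1cn([C@@H]2O[C@H](CO)[C@@H](O)[C@H]2O)c2nc(N)nc(OC)c12` carries an ethynyl group and a methoxy group on its core. In this assay compound 3 gives > 20000 nM, also a limit. Compound 1 thus stands at the limit of > 100000 nM in this assay, at which 1 of the 3 values shown sits, and the other two sit at the limit of > 20000 nM in this assay, at which 2 of the 3 values shown sit; none of the three yields a number.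

Compound 4 `Cc1nc(N)c2c(-c3cc4ccccc4o3)cn([C@@H]3O[C@H](CO)[C@@H](O)[C@H]3O)c2n1` has not been measured. It differs from compound 1 as follows: 1-benzofuran-2-yl in place of phenyl on an aromatic carbon. No measured step here involves this change, and since every shown value is a limit, no direction can be read from them. Compound 4 is therefore expected to give about 20000 nM, with a range from 2000 nM to 100000 nM, and the step of an at least 5.0-fold lower number from compound 1 to compound 4 (0.69 log units; beyond the scatter) is an estimate carrying wide uncertainty.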

Compound 4, half-maximal inhibitory concentration: > 20000 nM
Compound 4 was reported as a limit; the forecaster's own chance of this, stated with the estimate: 55%; the middle value sits exactly at the limit.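

In this assay compound 4 gives > 20000 nM, which is a limit of the assay and not a number. Compound 1 also stands at a limit, and the step between compound 1 and compound 4 cannot be read. The compounds shown leave open whether 1-benzofuran-2-yl in place of phenyl changes anything, and whether any group on the shared core gives an actual number in this assay.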